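A few compounds are considered here, and "the series" means these few. Any claim that something is new, unique, unknown or untested is made for them only; others in the source may bear on it.

Working notes on the cinnamate ester series.

Compound 1 `COc1ccc(/C=C/C(=O)OCCCCOc2cc(Cl)ccc2Oc2ccc(Cl)cc2Cl)cc1OC` is the reference with the longer chain; in an ADME assay on U-937 cells (Homo sapiens) for cytotoxicity, read by MTT assay, with a stated time of 72 h (on this read-out higher numbers stand for lower toxicity in this test and lower numbers for higher toxicity in this test), compound 1 gives 73400 nM. Compound 2 `O=C(/C=C/c1ccc(O)c(O)c1)OCCCCOc1cc(Cl)ccc1Oc1ccc(Cl)cc1Cl` keeps that chain and differs only in the change (3,4-dihydroxyphenyl in place of 3,4-dimethoxyphenyl on a double-bonded chain carbon bound to a double-bonded chain carbon). In this assay compound 2 gives 12000 nM, so the step of a 6.1-fold lower number from compound 1 to compound 2 (0.79 log units; beyond the scatter) is the one measured effect of this change on the read-out.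

Compound 3 `COc1ccc(/C=C/C(=O)OCCCOc2cc(Cl)ccc2Oc2ccc(Cl)cc2Cl)cc1OC` carries the shorter chain; how its core differs from that of compound 1 is not broken down here. In this assay, for the measured compounds named here, compound 3 is reported only as a limit, > 371000 nM, and the limit of > 371000 nM in this assay, at which 1 of the 3 values shown sits, is the only evidence on where it stands.

Compound 4 `O=C(/C=C/c1ccc(O)c(O)c1)OCCCOc1cc(Cl)ccc1Oc1ccc(Cl)cc1Cl` is not yet measured. Going by the values given here, it relates to compound 3 through the change (3,4-dihydroxyphenyl in place of 3,4-dimethoxyphenyl on a double-bonded chain carbon bound to a double-bonded chain carbon), the same change as the one from compound 1 to compound 2. Because a 6.1-fold lower number from compound 1 to compound 2 (0.79 log units; beyond the scatter) was observed on the longer chain, a step of similar size and direction is expected here, and the estimate is an at least 4.1-fold lower number from compound 3 to compound 4 (0.61 log units; beyond the scatter). Since the starting point for compound 3 is only a limit, the expected value for compound 4 is 90000 nM, with a wide range from 25000 nM to 400000 nM.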

Compound 4, concentration lethal to 50% of the cells: > 392000 nM
Compound 4: no number, only a limit; the forecaster's own chance of this, stated with the estimate: 35%; middle value at least 4.3-fold (0.63 log units) from the limit.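

In this assay, for the compounds shown here, compound 3 and compound 4 are each reported only as a limit, so no step between them can be read. The compounds shown leave open whether 3,4-dihydroxyphenyl in place of 3,4-dimethoxyphenyl changes the read-out on the chain of compound 3 and compound 4 as it does on the chain of compound 1 and compound 2.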